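Aryl thiosemicarbazones: methoxy for methyl on the aromatic ring

The source may hold more compounds than are shown below. What is called first, only, known or untested is meant among the compounds shown, and "the series" means these compounds.

Measured compounds:
compound 1 `CC1=CC[C@@H]([C@@](C)(O)CCCC(C)(C)NC(=S)N/N=C\c2ccccc2)CC1`; in a functional assay on NCI-H460 cells (Homo sapiens) for cytotoxicity, read by sulforhodamine B assay (a lower number here means a stronger inhibitor of growth, a higher number a weaker inhibitor of growth), compound 1 gives > 100000 nM
compound 2 `CC1=CC[C@@H]([C@@](C)(O)CCCC(C)(C)NC(=S)N/N=C\c2ccc(C)cc2)CC1`; in this assay compound 2 gives > 100000 nM

Both values are limits of the assay and not numbers. Compound 2 therefore stands at the limit of > 100000 nM in this assay, at which 2 of the 2 values shown sit, with no measured number of its own. For the measured compounds named here, the only step available, a step that the two limits leave unreadable from compound 1 to compound 2, is unreadable between the two limits, so it gives no direction. Compound 3 `COc1ccc(/C=N\NC(=S)NC(C)(C)CCC[C@](C)(O)[C@@H]2CC=C(C)CC2)cc1` carries methoxy in place of methyl on an aromatic carbon. Going by the values given here, no measured step bears readably on this change, and compound 1 and compound 2 both sit at the limit. Compound 3 is expected to stay near that limit, with a step that the limit leaves unreadable from compound 2 to compound 3 as the expected step, giving an estimate of 150000 nM (range 30000 nM to 600000 nM).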

Compound 3, concentration for total growth inhibition: > 100000 nM
Compound 3 ended at the assay's limit; the forecaster's own chance of this, stated with the estimate: 85%; the middle value lies beyond the limit too.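

No step can be read among compound 1, compound 2 and compound 3, as each gives only a limit in this assay: the limit of > 100000 nM in this assay, at which 3 of the 3 values shown sit.

On these data alone, whether any substituent on the aromatic ring changes growth inhibition, and in which direction, remains open.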